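The compounds below may be only part of what the source reports. "The series", "measured", "known", "first", "only" and "open" are said of these compounds alone.

Measured compounds:
compound 1, `CC(/C=N/Nc1ccc([N+](=O)[O-])cc1)=N\NC(=O)c1ccccc1O`: 1640 nM
compound 2, `CC(/C=N/Nc1ccc([N+](=O)[O-])cc1)=N\NC(=O)c1ccccc1N`: 4900 nM

In a functional assay on cells (Splenocyte, Mus musculus, strain BALB/c) for inhibition, read by scintillation counting and thymidine incorporation, with a stated time of 72 h (a higher number here means a weaker inhibitor, a lower number a stronger inhibitor), compound 1 gives 1640 nM, the lowest of the two numbers shown. Within the data shown here, its only measured neighbour is compound 2, which gives 4900 nM; the one step available, a 3.0-fold higher number from compound 1 to compound 2 (0.48 log units; beyond the scatter), is the exchange of amino for hydroxy on the aromatic carbon of the benzoyl hydrazide part, and it lies beyond the scatter.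

Compound 3, `CC(/C=N/N(C)c1ccc([N+](=O)[O-])cc1)=N\NC(=O)c1ccccc1O`, differs from compound 1 by methyl in place of hydrogen on a nitrogen on an aromatic ring. Among the measured compounds shown here, no measured pair touches this nitrogen, so the step from compound 2 bears on it only as a sign that the series can move modestly with a small change. With nothing closer to go on, the expectation for compound 3 is a step of a 1.5-fold higher number from compound 1 to compound 3 (0.18 log units; within the scatter), wide in either direction, with the estimate for compound 3 in this assay at 2500 nM, between 800 nM and 8000 nM.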

Compound 3, half-maximal inhibitory concentration: 3120 nM
Estimate against measurement, compound 3: 1.2-fold (0.10 log units) below, within the range that was stated.
By their numbers in this assay, from the lowest: compounds 1, 3 and 2 (each within the scatter of the next, the first and the last beyond it).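

In this assay, the pair at this nitrogen gives a 1.9-fold higher number from compound 1 to compound 3 (0.28 log units; within the scatter), so methyl in place of hydrogen on a nitrogen on an aromatic ring leaves the number within the scatter, and the hydrogen at this place is not required to keep activity in this range. The earlier step concerned a different place, amino in place of hydroxy on an aromatic carbon, and it lay beyond the scatter, whereas this step at the nitrogen does not. No measurement shown here offers an explanation for this result.

From the compounds shown here alone, whether an ethyl group, a longer chain or an acetyl group on this nitrogen would also stay within the scatter of compound 1 remains open. Also open, going by these compounds, is how methyl on this nitrogen would behave alongside the amino group of compound 2, as compound 2 and compound 3 differ in two places.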